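From compound 3 to compound 4: a methyl on nitrogen

The compounds below may be only part of what the source reports. "The series", "measured", "known", "first", "only" and "open" are said of these compounds alone.

In an assay on isolated protein for inhibition of high affinity nerve growth factor receptor (Homo sapiens), read by 33P incorporation (on this read-out higher numbers stand for weaker inhibition and lower numbers for stronger inhibition), the three measured compounds gave the following numbers:
compound 1 `CC(=O)Nc1cccc(-c2cnc3[nH]cc(-c4ccncc4)c3c2)c1`: 34.3 nM
compound 2 `Cc1ccc(S(=O)(=O)Nc2cc(N)cc(-c3cnc4[nH]cc(-c5ccncc5)c4c3)c2)cc1`: 4.62 nM
compound 3 `Nc1cccc(-c2cnc3[nH]cc(-c4ccncc4)c3c2)c1`: 42.7 nM

Compound 3 holds the highest of these three numbers. Compound 1 lies within the scatter of it, a 1.2-fold higher number from compound 1 to compound 3 (0.10 log units; within the scatter), while compound 2 sits further off, a 9.2-fold higher number from compound 2 to compound 3 (0.97 log units; beyond the scatter). Compound 4 `CNc1cccc(-c2cnc3[nH]cc(-c4ccncc4)c3c2)c1` differs from compound 3 by methyl in place of hydrogen on a nitrogen on an aromatic ring. For the measured compounds named here, the step that bears on this change is the one from compound 1 to compound 3, since it also varies the substituent on that nitrogen and stayed within the scatter; the step from compound 2 concerns another position and weighs less. In this assay no step beyond the scatter is therefore expected, a 1.1-fold lower number from compound 3 to compound 4 (0.03 log units; within the scatter). Compound 4 is estimated at 40 nM, within 15 nM to 110 nM.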

Compound 4, half-maximal inhibitory concentration: 31.4 nM
For compound 4 the middle estimate is 1.3-fold (0.11 log units) above the measured one; the measured number falls inside the stated range.
By their numbers in this assay, from the lowest: compound 2; then compounds 4, 1 and 3 (each within the scatter of the next).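

In this assay, methyl on this nitrogen stays within the scatter of hydrogen (a 1.4-fold lower number from compound 3 to compound 4 (0.13 log units; within the scatter)), and methyl in place of acetyl does too (a 1.1-fold lower number from compound 1 to compound 4 (0.04 log units; within the scatter)). Hydrogen, methyl and acetyl on the nitrogen on the aromatic ring therefore cannot be told apart in this assay, so the position has so far tolerated all three groups without a step beyond the scatter. Nothing available accounts for this result.
On these data alone, it remains open whether a longer chain such as butyl, a second methyl on the same nitrogen or a benzoyl group would give a step beyond the scatter.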